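A smaller fluorophenyl in place of a trifluoromethylphenyl

The source may report more compounds than this note shows. Statements on the series, on what has been measured and on what is new or still open speak of the compounds shown alone.

Compound 1 `N#Cc1ccc(Nc2nc(Oc3ccnc4ccccc34)nc(N3CCN(c4cccc(C(F)(F)F)c4)CC3)n2)cc1C(F)(F)F`: in a functional assay on DU-145 cells (Homo sapiens) for cytotoxicity, read by sulforhodamine B assay, with a stated time of 48 h (on this read-out higher numbers stand for weaker inhibition of growth and lower numbers for stronger inhibition of growth), compound 1 gives 74100 nM.
Compound 2 `N#Cc1ccc(Nc2nc(Oc3ccnc4ccccc34)nc(N3CCN(C(c4ccccc4)c4ccccc4)CC3)n2)cc1C(F)(F)F`: in this assay compound 2 gives only a limit of the assay, > 100000 nM.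

Going by the values given here, compound 1 stands as the only value in this set given as a number. The other result sits at a limit of the assay (the limit of > 100000 nM in this assay, at which 1 of the 2 values shown sits). Compound 3 `N#Cc1ccc(Nc2nc(Oc3ccnc4ccccc34)nc(N3CCN(c4ccccc4F)CC3)n2)cc1C(F)(F)F` differs from compound 1 by 2-fluorophenyl in place of 3-(trifluoromethyl)phenyl on an amine nitrogen in a ring. Among the compounds with values here, no measured step of this kind is available, so the change is expected to move the number no further than the usual scatter. Compound 3 is therefore expected to give 80000 nM, between 30000 nM and 200000 nM, which amounts to an expected 1.1-fold higher number from compound 1 to compound 3 (0.03 log units; within the scatter).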

Compound 3, concentration for total growth inhibition: > 100000 nM
Compound 3: no number, only a limit (the forecaster's own chance of this, stated with the estimate: 40%); middle value at least 1.2-fold (0.09 log units) away from the limit.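

Placing 2-fluorophenyl on this amine nitrogen in place of 3-(trifluoromethyl)phenyl gives, in this assay, an at least 1.3-fold higher number from compound 1 to compound 3 (0.13 log units; that floor lies within the scatter). On these data alone, the smaller group therefore brings no measurable gain in growth inhibition here, yet the true distance between the two compounds stays unknown, and the printed floor does not clear the usual scatter. Compound 1 remains the only compound with a real number, and the others stop at the ceiling of the assay: the limit of > 100000 nM in this assay, at which 2 of the 3 values shown sit.

Still open, as far as these compounds go, is whether an unsubstituted phenyl, or a phenyl carrying an amine or a carboxylic acid, at this nitrogen would give a number rather than a limit.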